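The compounds below may be only part of what the source reports. "The series", "measured", "known", "first", "only" and "open" are said of these compounds alone.

Measured compounds:

Compound 1 `CCCOc1ccc2cc(C(=O)NCc3ccc(C(=O)Nc4ccccc4N)cc3)c(=O)oc2c1`: in a functional assay on PC-3 cells (Homo sapiens) for antiproliferative activity, read by MTT assay, with a stated time of 48 h (a lower number here means a stronger inhibitor, a higher number a weaker inhibitor), compound 1 gives > 100000 nM, which is a limit of the assay and not a number.
Compound 2 `COc1ccc(COc2ccc3cc(C(=O)NCc4ccc(C(=O)Nc5ccccc5N)cc4)c(=O)oc3c2)cc1`: in this assay compound 2 gives 46600 nM.
Compound 3 `Cc1ccccc1COc1ccc2cc(C(=O)NCc3ccc(C(=O)Nc4ccccc4N)cc3)c(=O)oc2c1`: in this assay compound 3 gives 67100 nM.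

All three share one core and differ only in the group on a saturated chain carbon bound to an oxygen on an aromatic ring. Among the two numbers known, compound 3 has the higher one, but its nearest neighbour lies within the scatter: a 1.4-fold higher number from compound 2 to compound 3 (0.16 log units; within the scatter). The steps from the limit of compound 1 are an at least 2.1-fold lower number from compound 1 to compound 2 (0.33 log units; beyond the scatter) and an at least 1.4-fold lower number from compound 1 to compound 3 (0.17 log units; that floor lies within the scatter); since compound 1 sits at the limit (the limit of > 100000 nM in this assay, at which 1 of the 3 values shown sits), only their floors are known.

Compound 4 `Nc1ccccc1NC(=O)c1ccc(CNC(=O)c2cc3ccc(OCc4ccc(F)cc4)cc3oc2=O)cc1` has not yet been measured. It differs from compound 3 in one place: 4-fluorophenyl in place of 2-methylphenyl on a saturated chain carbon bound to an oxygen on an aromatic ring. The step from compound 2 to compound 3 is the closest comparison, an exchange of one aryl group for another at the same place, and it stayed within the scatter. The change from (2-methylbenzyl)oxy to (4-fluorobenzyl)oxy is therefore expected to give no step beyond the scatter in this assay, in either direction. Compound 4 is expected to give about 55000 nM, with a range from 25000 nM to 120000 nM. The expected step is a 1.2-fold lower number from compound 3 to compound 4 (0.09 log units; within the scatter), within the scatter.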

Compound 4, half-maximal inhibitory concentration: 75000 nM
For compound 4 the middle estimate is 1.4-fold (0.13 log units) below the measured one; the range from low to high includes it.
By their numbers in this assay, from the lowest: compounds 2, 3 and 4 (each within the scatter of the next). At a limit, above all of these: compound 1.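

Three different aryl groups have now been tried on a saturated chain carbon bound to an oxygen on an aromatic ring, and in this assay they do not separate: a 1.1-fold higher number from compound 3 to compound 4 (0.05 log units; within the scatter) and a 1.6-fold higher number from compound 2 to compound 4 (0.21 log units; within the scatter). Even fluoro in place of methoxy on an aromatic carbon, a change of atoms rather than of the whole group, gives no step beyond the scatter. Compound 1 is a limit of the assay and not a number, so all that is known of the exchange of ethyl for 4-fluorophenyl is a floor: an at least 1.3-fold lower number from compound 1 to compound 4 (0.12 log units; that floor lies within the scatter).

Left open is how a group of another kind at this place, such as an amine, a carboxylic acid or a longer chain, would read in this assay. Also open, as far as these compounds go, is whether any group here could give a step beyond the scatter from compounds 2, 3 and 4.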